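Methoxy on the Aryl Ring of a Neopentyl Aminothiophene Core

A few compounds are considered here, and "the series" means these few. Any claim that something is new, unique, unknown or untested is made for them only; others in the source may bear on it.

Three aminothiophene ketones have been measured in an assay on CHO cells for displacement of a labelled ligand from adenosine receptor A3 (Homo sapiens), read by scintillation counting, tested at 10 uM; a higher number here means more inhibition at the concentration tested (going by the name of the read-out), a lower number less inhibition. Compound 1 `Cc1c(-c2ccccc2)sc(N)c1C(=O)c1ccc(Cl)cc1` gives 1% in this assay. Compound 2 `COc1ccc(-c2sc(N)c(C(=O)c3ccc(Cl)cc3)c2C)cc1` carries methoxy in place of hydrogen on an aromatic carbon and gives 1% in this assay; the step of no change at the digits printed from compound 1 to compound 2 (within the scatter). Compound 3 `CC(C)(C)Cc1c(-c2ccccc2)sc(N)c1C(=O)c1ccc(Cl)cc1` instead carries tert-butyl in place of hydrogen on a saturated chain carbon bound to an aromatic carbon and gives 1% in this assay; the step of no change at the digits printed from compound 1 to compound 3 (within the scatter). Compound 3 thus stands level with compound 1 and compound 2, and none of the three shows anything that rises above the scatter of this assay.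

Compound 4 `COc1ccc(-c2sc(N)c(C(=O)c3ccc(Cl)cc3)c2CC(C)(C)C)cc1` has not yet been measured in this assay. It is compound 3 with methoxy in place of hydrogen on an aromatic carbon. This is the same change that leads from compound 1 to compound 2, and it sits at the same place in both pairs, on an aromatic carbon of the six-membered carbon ring, para to a large group. The two cores differ in tert-butyl in place of hydrogen on a saturated chain carbon bound to an aromatic carbon.

Since the step of no change at the digits printed from compound 1 to compound 2 (within the scatter) left the read-out unchanged, and since compound 3 already sits at 1%, the author expects the step from compound 3 to compound 4 to be no change at the digits printed from compound 3 to compound 4 (within the scatter) in this assay. Compound 4 is therefore estimated at 1% in this assay, with a range from -8% to 12% expected.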

Compound 4, a percentage reported as inhibition, at one concentration (the size of the read-out at that concentration, not a potency): 2%
The estimate for compound 4 lay 1 percentage points below the measured number, within the range that was stated.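

Methoxy in place of hydrogen on an aromatic carbon, the change from phenyl to 4-methoxyphenyl, gives a number 1 percentage points higher from compound 3 to compound 4 (within the scatter) in this assay, and on the two cores it reads alike: the same change on two cores in this assay, no change at the digits printed (within the scatter) from compound 1 to compound 2 and a number 1 percentage points higher (within the scatter) from compound 3 to compound 4, 1 percentage points apart, within the scatter of two such steps. Tert-butyl in place of hydrogen on a saturated chain carbon bound to an aromatic carbon gives a number 1 percentage points higher from compound 2 to compound 4 (within the scatter), and this change also reads alike on the two cores: the same change on two cores in this assay, no change at the digits printed (within the scatter) from compound 1 to compound 3 and a number 1 percentage points higher (within the scatter) from compound 2 to compound 4, 1 percentage points apart, within the scatter of two such steps. Among these compounds, the agreement shows only that neither change produced a read-out above the scatter on either core; with all four compounds this low at a single concentration, it does not show that a real effect of methoxy would carry from one core to another, and it gives no measure of potency.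

The compounds shown leave open whether a different group in place of the same aromatic hydrogen, such as an amine or a carboxylic acid, would lift the inhibition in this assay above the scatter. They also leave open whether a longer chain in place of tert-butyl would do so, and whether any such gain would then carry from one core to the other.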